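A few compounds are considered here, and "the series" means these few. Any claim that something is new, unique, unknown or untested is made for them only; others in the source may bear on it.

Among the measured compounds shown here, in an ADME assay on MRC5 cells (Homo sapiens) for cytotoxicity, read by fluorescence and resazurin assay, with a stated time of 3 days (a lower number here means a stronger inhibitor, a higher number a weaker inhibitor), compound 3 `COc1cccc(Oc2cccc(CN3CCC(n4cc(C)c(=O)[nH]c4=O)CC3)c2)c1` gives 25300 nM, the only actual number among the compounds measured so far. Compound 1 `Cc1cn(C2CCN(Cc3cccc(Oc4cccnc4)c3)CC2)c(=O)[nH]c1=O` reads > 64000 nM, which is a limit of the assay and not a number. Compound 2 `Cc1cn(C2CCN(Cc3cccc(Oc4ccccc4)c3)CC2)c(=O)[nH]c1=O` offers no result, and its entry reads "not determined" (no result reported).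

Compound 4 `Cc1cn(C2CCN(Cc3cccc(Oc4ccc(Cl)c(Cl)c4)c3)CC2)c(=O)[nH]c1=O` differs from compound 3 in one place, with 3,4-dichlorophenyl in place of 3-methoxyphenyl on an oxygen on an aromatic ring. For the measured compounds named here, only one measured step bears on this place, an at least 2.5-fold lower number from compound 1 to compound 3 (0.40 log units; beyond the scatter), where 3-methoxyphenyl took the place of pyridin-3-yl. That step lies beyond the scatter, and its starting point is the limit of > 64000 nM in this assay, at which 1 of the 3 values shown sits. It is a single step, and a different group entered there, so it gives only a rough guide. Going by that step, an at least 2.5-fold lower number from compound 1 to compound 3 (0.40 log units; beyond the scatter), a further modest move towards a lower number in this assay is expected, though a result close to compound 3 would not be surprising. The expected change is a 2.1-fold lower number from compound 3 to compound 4 (0.32 log units; beyond the scatter). For compound 4 the estimated value is 12000 nM, with an expected range from 5000 nM to 30000 nM.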

Compound 4, half-maximal inhibitory concentration: 6100 nM
Beside the measured number, compound 4's estimate is 2.0-fold (0.29 log units) above it, and the stated range covers the measured number.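

In this assay, this place, on an oxygen on an aromatic ring, now shows a second step beyond the scatter, a 4.1-fold lower number from compound 3 to compound 4 (0.62 log units; beyond the scatter), so the number also falls when one carbon-only ring replaces another, and not only when such a ring replaces pyridin-3-yl. The 3-methoxyphenyl and 3,4-dichlorophenyl groups have the same heavy-atom count, so this step comes with no change in that count, only a change in which atoms the ring carries, and the widest step at this place is now an at least 10-fold lower number from compound 1 to compound 4 (1.02 log units; beyond the scatter). The size of that wider step is only a bound, since the value of compound 1 is a limit of the assay and not a number: the limit of > 64000 nM in this assay, at which 1 of the 4 values shown sits.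

The compounds shown leave open whether a single chlorine on the phenyl ring would give all or only part of the step, and whether the order of the two chlorines on the ring matters. They also leave open how a phenyl ring carrying an amine or a carboxylic acid at this place would read in this assay.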